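This account rests on a few compounds, and the source may have more. Where it says the series, first, only, none or still open, it means among the compounds named here.

Measured compounds, with their values in a functional assay on A549 cells (Homo sapiens) for inhibition, read by MTT assay, with a stated time of 48 h; a higher number here means a weaker inhibitor, a lower number a stronger inhibitor:
compound 1 `COc1ccc2c(=O)c(/C=C/C(=O)Nc3cccc(C)c3)coc2c1`: > 100000 nM, a limit of the assay and not a number.
compound 2 `COc1cccc(NC(=O)/C=C/c2coc3cc(OC)ccc3c2=O)c1`: 12800 nM
compound 3 `COc1ccc(NC(=O)/C=C/c2coc3cc(OC)ccc3c2=O)cc1`: 23000 nM

Compound 3 holds the highest of the two numbers shown, with compound 2 nearest; the gap a 1.8-fold higher number from compound 2 to compound 3 (0.25 log units; within the scatter) lies within the scatter, so no order is claimed between the two. Compound 4 `COc1ccc2c(=O)c(/C=C/C(=O)Nc3ccc(C)cc3)coc2c1` has not yet been measured. It differs from compound 3 by methyl in place of methoxy on an aromatic carbon. Among the compounds with values here, one measured step bears on this change, run in the reverse direction: an at least 7.8-fold lower number from compound 1 to compound 2 (0.89 log units; beyond the scatter). Compound 1 sits at the limit of the assay. Methyl in place of methoxy is therefore expected to raise the number in this assay by a step of at least modest size, though the limit of > 100000 nM in this assay, at which 1 of the 3 values shown sits, leaves the exact size of that step open. For compound 4 the expected step is a 3.5-fold higher number from compound 3 to compound 4 (0.54 log units; beyond the scatter). Compound 4 is accordingly estimated at 80000 nM, with a range from 25000 nM to 300000 nM, and a fair chance that the assay returns only a limit.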

Compound 4, half-maximal inhibitory concentration: 17500 nM
Compound 4: the middle estimate sits 4.6-fold (0.66 log units) above what was measured, and the stated range ends above it.
By their numbers in this assay, from the lowest: compounds 2, 4 and 3 (each within the scatter of the next). At a limit, above all of these: compound 1.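

In this assay, methyl and methoxy cannot be told apart as 4-substituents on this phenyl: a 1.3-fold lower number from compound 3 to compound 4 (0.12 log units; within the scatter), and compound 4 also stays within the scatter of the 3-methoxyphenyl analogue, a 1.4-fold higher number from compound 2 to compound 4 (0.14 log units; within the scatter). As far as these compounds go, the methyl group therefore does not by itself go with a weak result, since 4-methylphenyl in place of 3-methylphenyl gives an at least 5.7-fold lower number from compound 1 to compound 4 (0.75 log units; beyond the scatter), and the same methoxy-methyl change reads differently on the two cores: the same change on two cores in this assay, an at least 7.8-fold lower number (0.89 log units; beyond the scatter) from compound 1 to compound 2 and a 1.3-fold higher number (0.12 log units; within the scatter) from compound 4 to compound 3, at least 10-fold (1.01 log units) apart, beyond the scatter of two such steps Compound 1 gives > 100000 nM, a limit of the assay and not a number, so the true size of the steps from it stays open.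

From the compounds shown here alone, what an amine or a carboxylic acid would give at this position stays open. With only methyl and methoxy shown on this phenyl, the data do not say why compound 1 stands apart from compound 4.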